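Methyl on the triazole of an ortho-substituted imidazoline

The source may hold more compounds than are shown below. What is called first, only, known or untested is meant among the compounds shown, and "the series" means these compounds.

Compound 3, `c1ccc(-c2nc[nH]n2)c(NCC2=NCCN2)c1`: 5.01 nM
Compound 1, `Cc1nc(-c2ccccc2NCC2=NCCN2)n(C)n1`: < 5020 nM
Compound 2, `CCn1cccc1-c1ccccc1NCC1=NCCN1`: < 100000 nM

Of the compounds shown here, three have been tested in an in vitro functional assay on cells (Fibroblast) for agonist activity at Alpha-1B adrenergic receptor (Homo sapiens); on this read-out higher numbers stand for an effect only at larger amounts of compound and lower numbers for an effect already at smaller amounts. For compound 1 the result is a limit, < 5020 nM, and not a number (the limit of < 5020 nM in this assay, at which 1 of the 3 values shown sits). For compound 2 the result is likewise a limit, < 100000 nM (the limit of < 100000 nM in this assay, at which 1 of the 3 values shown sits). Among the compounds with values here, compound 3 is therefore the only compound with a number on this assay, 5.01 nM, and no step between two measured compounds can be drawn from these three.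

Compound 4, `Cc1n[nH]c(-c2ccccc2NCC2=NCCN2)n1`, has not been measured. It differs from compound 3 in one place: 3-methyl-1H-1,2,4-triazol-5-yl in place of 1H-1,2,4-triazol-3-yl on an aromatic carbon. The methyl is added on a five-membered aromatic ring that is otherwise kept, and the hydrogen-bond donor count is unchanged.

Within the data shown here, with no measured step to lean on, the expected step from compound 3 to compound 4 is small, a 3.0-fold higher number from compound 3 to compound 4 (0.48 log units; beyond the scatter), most likely a modest loss in this assay that may not exceed the usual scatter. Compound 4 is estimated at 15 nM, within 3 nM to 80 nM.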

Compound 4, half-maximal effective concentration: < 5020 nM
Compound 4 was reported as a limit (the forecaster's own chance of this, stated with the estimate: 5%); the middle value does not contradict the limit.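

The result for compound 4 is a limit and not a number, so neither the step from compound 3 to compound 4 nor the step from compound 1 to compound 4 can be read. The compounds shown leave open whether the 3-methyl-1H-1,2,4-triazol-5-yl group shifts the response at all in this assay.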